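The source may hold more compounds than are shown below. What is called first, only, known or untested is meant among the compounds shown, and "the series" means these compounds.

Three compounds share one core and differ only in the group on an aromatic carbon. Compound 1 `CCC(C)(C)Cc1c[nH]c(CCc2ccc(-c3ccncc3)cc2)n1` gives 95 nM in a functional assay on HEK293 cells for agonist activity at Bombesin receptor subtype-3 (Homo sapiens), read by luminescence and calcium flux, with a stated time of 10 min; on this read-out lower numbers stand for an effect already at smaller amounts and higher numbers for an effect only at larger amounts of compound. Compound 2 `CCC(C)(C)Cc1c[nH]c(CCc2ccc(-n3ccnn3)cc2)n1` gives 93 nM in this assay, and compound 3 `CCC(C)(C)Cc1c[nH]c(CCc2ccc(-n3cncn3)cc2)n1` gives 89 nM in this assay. Compound 3 carries the lowest of the three numbers, yet every gap sits within the scatter: a 1.1-fold lower number from compound 1 to compound 3 (0.03 log units; within the scatter), a 1.0-fold lower number from compound 2 to compound 3 (0.02 log units; within the scatter), and likewise a 1.0-fold lower number from compound 1 to compound 2 (0.01 log units; within the scatter). Compound 4 `CCC(C)(C)Cc1c[nH]c(CCc2ccc(N3CCCCC3)cc2)n1` has not yet been tested in this assay. The change from compound 3 is piperidin-1-yl in place of 1H-1,2,4-triazol-1-yl on an aromatic carbon. For the measured compounds named here, the three measured steps bear on this only in part: each exchanged one aromatic group for another aromatic group at the same place and left the number essentially unchanged, whereas here a non-aromatic ring enters, and no measured step shows what that does. One therefore expects no step beyond the scatter, a 1.1-fold higher number from compound 3 to compound 4 (0.05 log units; within the scatter), though with less certainty than among the measured compounds. Compound 4 is estimated at 100 nM, within a range from 30 nM to 350 nM.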

Compound 4, half-maximal effective concentration: 108 nM
Beside the measured number, compound 4's estimate is 1.1-fold (0.03 log units) below it; the range from low to high includes it.
By their numbers in this assay, from the lowest: compounds 3, 2, 1 and 4 (each within the scatter of the next).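

In this assay, the place on an aromatic carbon para to a large group also accepts a non-aromatic ring: piperidin-1-yl gives a 1.2-fold higher number from compound 3 to compound 4 (0.08 log units; within the scatter), a 1.2-fold higher number from compound 2 to compound 4 (0.06 log units; within the scatter) and a 1.1-fold higher number from compound 1 to compound 4 (0.06 log units; within the scatter). Across these four compounds, then, neither the loss of aromaticity in this ring nor the drop from 3 hydrogen-bond acceptors in 1H-1,2,4-triazol-1-yl to 1 in piperidin-1-yl comes with a step beyond the scatter. No measurement at hand accounts for this flat result.

On these data alone, all four groups are rings, so it remains open how an open-chain amine, a carboxylic acid or a single fluorine atom would fare at this place. As far as these compounds go, whether any group here can move the number beyond the scatter also remains open.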